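Replacing the azole on a shared fluoronaphthyl scaffold

The compounds below may be only part of what the source reports. "The series", "measured", "known", "first", "only" and "open" are said of these compounds alone.

In an assay on CHO cells for displacement of a labelled ligand from prostaglandin E2 receptor EP3 subtype (Homo sapiens), read by radioligand binding (a lower number here means a stronger inhibitor, a higher number a weaker inhibitor), the two measured compounds stand as follows:
compound 1 `CC(C)C(c1ccc(-c2ccc3cccc(F)c3c2)[nH]c1=O)N1CCCCC1=O` gives 6.4 nM
compound 2 `Cc1nc(C(c2ccc(-c3ccc4cccc(F)c4c3)[nH]c2=O)C(C)C)[nH]c1C` gives 7 nM

Within the data shown here, compound 2 holds the higher of the two numbers in this assay, yet the only measured step, a 1.1-fold higher number from compound 1 to compound 2 (0.04 log units; within the scatter), lies within the scatter, so the two compounds cannot be ordered. Compound 3 `CC(C)C(c1noc(=O)[nH]1)c1ccc(-c2ccc3cccc(F)c3c2)[nH]c1=O` differs from compound 2 by a group of 6 heavy atoms (2 carbon, 2 nitrogen, 2 oxygen; one five-membered aromatic ring with 3 hetero atoms) in place of a group of 7 heavy atoms (5 carbon, 2 nitrogen; one five-membered aromatic ring with 2 hetero atoms), on a saturated chain carbon bound to an aromatic carbon and a saturated chain carbon. Among the measured compounds shown here, that single step bears on the same place and was within the scatter; the incoming group has no measured counterpart, so compound 3 is expected to show no step beyond the scatter, a 1.4-fold higher number from compound 2 to compound 3 (0.15 log units; within the scatter), with wide uncertainty. Compound 3 is therefore estimated at 10 nM, between 3 nM and 40 nM.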

Compound 3, inhibition constant: 15 nM
For compound 3 the middle estimate is 1.5-fold (0.18 log units) below the measured one; low and high end bracket the measured number.
By their numbers in this assay, from the lowest: compounds 1 and 2 (each within the scatter of the next); then compound 3.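

Among these compounds, the oxadiazolone-type group of compound 3 is the first at this place to leave a mark, with a 2.1-fold higher number from compound 2 to compound 3 (0.33 log units; beyond the scatter) and a 2.3-fold higher number from compound 1 to compound 3 (0.37 log units; beyond the scatter) both printed as modest steps in this assay on the shared core. The saturated chain carbon bound to an aromatic carbon and a saturated chain carbon is therefore not indifferent to what it carries, though the change stays small. No measurement at hand accounts for this step. From the compounds shown here alone, whether a carboxylic acid or an amine on that carbon would move the number further remains open.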